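Working notes: from iodo compound 2 to bromo compound 4

The source may report more compounds than this note shows. Statements on the series, on what has been measured and on what is new or still open speak of the compounds shown alone.

Measured in a functional assay on KBVIN cells (Homo sapiens) for antiproliferative activity, read by sulforhodamine B assay, with a stated time of 3 days; on this read-out lower numbers stand for an effect already at smaller amounts and higher numbers for an effect only at larger amounts of compound:
- compound 1 `CCCC1=C(OC)C(CCC)(CCC)C(=O)/C(=C(O)\C=C\c2ccccc2)C1=O`: 3.4 uM
- compound 2 `CCCC1=C(OC)C(CCC)(CCC)C(=O)/C(=C(O)\C=C\c2ccc(I)cc2)C1=O`: 1.4 uM
- compound 3 `CCCCOC1=C(CCC)C(=O)/C(=C(O)/C=C/c2ccccc2)C(=O)C1(CCC)CCC`: 8.9 uM

Of the three measured compounds, compound 2 has the lowest number in this assay, at 1.4 uM, and its steps to the other two lie beyond the scatter. The next analogue is compound 4 `CCCC1=C(OC)C(CCC)(CCC)C(=O)/C(=C(O)\C=C\c2ccc(Br)cc2)C1=O`, with bromo in place of iodo on an aromatic carbon, para to a large group: bromo in place of iodo on an aromatic carbon.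

The most relevant measured change is iodo in place of hydrogen on an aromatic carbon, a 2.4-fold lower number from compound 1 to compound 2 (0.39 log units; beyond the scatter), a modest step. The other measured change, a 2.6-fold higher number from compound 1 to compound 3 (0.42 log units; beyond the scatter), is also modest but involves propyl in place of hydrogen on a saturated chain carbon, so it bears little on this swap. For the measured compounds named here, no measured pair compares two halogens directly.

A small rise in the number is expected, with compound 1 at 3.4 uM as a rough upper guide. The estimated change is a 1.3-fold higher number from compound 2 to compound 4 (0.11 log units; within the scatter), which is expected to be no larger than the scatter. For compound 4, the expected value is 1.8 uM, with an estimated range of 0.9 uM to 3.6 uM.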

Compound 4, concentration for half-maximal effect: 1.8 uM
Compound 4: middle estimate and measured number agree at the digits printed; low and high end bracket the measured number.
By their numbers in this assay, from the lowest: compounds 2, 4 and 1 (each within the scatter of the next, the first and the last beyond it); then compound 3.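

In this assay, the exchange of one halogen for the other on this aromatic carbon gives no step that can be told from the scatter (a 1.3-fold higher number from compound 2 to compound 4 (0.11 log units; within the scatter)), so iodo is not shown to be required here. Bromo in place of hydrogen stays within the scatter (a 1.9-fold lower number from compound 1 to compound 4 (0.28 log units; within the scatter)), whereas iodo in place of hydrogen lies beyond it (a 2.4-fold lower number from compound 1 to compound 2 (0.39 log units; beyond the scatter)), so only the iodo step separates from the unsubstituted compound 1, even though the two halogens cannot be separated from each other. No measurement at hand explains how either halogen acts at this position.

Open, on these data alone, is how chloro, fluoro, an amine or a carboxylic acid would read on the same aromatic carbon. Also open, as far as these compounds go, is whether iodo or bromo would give similar steps on the core of compound 3, with its butoxy chain.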